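The source may hold more compounds than are shown below. What is called first, only, known or untested is meant among the compounds shown, and "the series" means these compounds.

Compound 1 `CCOC(=O)CCO/N=C(/c1ccc(OC)c(OC)c1OC)c1cccc2ccccc12` carries an oxime ether chain on the shared core, ending in an ester. For the measured compounds named here, in a functional assay on HCT-116 cells (Homo sapiens) for inhibition, read by sulforhodamine B assay, with a stated time of 48 h (a higher number here means a weaker inhibitor, a lower number a stronger inhibitor), compound 1 gives 10000 nM, and among the values shown for this assay, compound 1 provides the only number. The other entry shown for this assay is a limit. Compound 2 `COc1ccc(C(OCc2ccccc2)c2cccc3ccccc23)c(OC)c1OC` is that other entry: in this assay compound 2 gives > 20000 nM, which is a limit of the assay rather than a number (the limit of > 20000 nM in this assay, at which 1 of the 2 values shown sits). Compound 3 `CCOC(=O)/C=C/CO/N=C(/c1ccc(OC)c(OC)c1OC)c1cccc2ccccc12` has not yet been measured in this assay. It differs from compound 1 in one place: 2-(ethoxycarbonyl)ethenyl in place of (ethoxycarbonyl)methyl on a saturated chain carbon bound to an oxygen on an unsaturated carbon. Going by the values given here, no step between two measured compounds is available to indicate how a change of this kind tends to move the read-out. The step from compound 1 to compound 3 is expected to be a 1.3-fold lower number from compound 1 to compound 3 (0.10 log units; within the scatter), a shift that stays within the usual scatter of the assay, with no direction claimed. Compound 3 is therefore estimated at 8000 nM, with a range from 3000 nM to 20000 nM.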

Compound 3, half-maximal inhibitory concentration: > 20000 nM
Compound 3 was reported as a limit; the forecaster's own chance of this, stated with the estimate: 30%; at least 2.5-fold (0.39 log units) between middle value and limit.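

For the compounds shown here, replacing (ethoxycarbonyl)methyl with 2-(ethoxycarbonyl)ethenyl on a saturated chain carbon bound to an oxygen on an unsaturated carbon gives an at least 2.0-fold higher number from compound 1 to compound 3 (0.30 log units; that floor lies within the scatter), the first step that can be read at this position, and it shows that this longer, unsaturated ester chain brings no gain in the read-out. In this assay compound 3 gives > 20000 nM, which is a limit and not a number, so the step is only a floor, and that floor does not by itself establish a change beyond the usual scatter. Compound 1 therefore remains the only one of the three compounds with a measured number, while the others reach the top of the range: the limit of > 20000 nM in this assay, at which 2 of the 3 values shown sit.

The compounds shown leave open how far compound 3 lies past its limit, and whether the double bond or the added chain length accounts for the step, since the saturated chain of the same length does not appear among them. They also leave open whether a carboxylic acid, an amide or an amine at the end of this chain would bring the number down.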